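Phenyl in Place of 2-Methylphenyl: Expected Value for Compound 4

This account rests on a few compounds, and the source may have more. Where it says the series, first, only, none or still open, it means among the compounds named here.

Measured so far:
compound 1, `CC(C)(C)Cc1c(-c2ccncc2)sc(N)c1C(=O)c1ccc(Cl)cc1`, 1% in an assay on CHO cells for displacement of a labelled ligand from adenosine receptor A1 (Homo sapiens), read by scintillation counting, tested at 10 uM; on this read-out lower numbers stand for less inhibition and higher numbers for more inhibition at the one concentration tested (going by the name of the read-out)
compound 2, `CC(C)(C)Cc1c(-c2c(F)cccc2F)sc(N)c1C(=O)c1ccc(Cl)cc1`, 1% in this assay
compound 3, `Cc1ccccc1-c1sc(N)c(C(=O)c2ccc(Cl)cc2)c1CC(C)(C)C`, 1% in this assay

On these numbers compound 3 stands level with compound 1 and compound 2; its nearest neighbour is compound 1 and its furthest is compound 2, and neither gap goes beyond the scatter. All three compounds share one core and differ only in the aryl group on an aromatic carbon of that core.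

Compound 4, `CC(C)(C)Cc1c(-c2ccccc2)sc(N)c1C(=O)c1ccc(Cl)cc1`, has not yet been measured in this assay. It differs from compound 3 by the following change: hydrogen in place of methyl on an aromatic carbon.

For the measured compounds named here, no measured step is this very change, so compound 3 can only be compared with compound 1 and compound 2, whose aryl groups differ from its own. The step of no change at the digits printed from compound 1 to compound 3 (within the scatter) and the step of no change at the digits printed from compound 2 to compound 3 (within the scatter) are both within the scatter, as is the step of no change at the digits printed from compound 1 to compound 2 (within the scatter). Three different aryl groups in this position gave the same read-out, so no step beyond the scatter is expected for compound 4 either.

Compound 4 is therefore estimated at 1% in this assay, with a range from -8% to 10%; the expected step is no change at the digits printed from compound 3 to compound 4 (within the scatter).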

Compound 4, a percentage reported as inhibition, at one concentration (the size of the read-out at that concentration, not a potency): 1%
Compound 4: middle estimate and measured number agree at the digits printed, within the range that was stated.
By their numbers in this assay, from the lowest: compounds 1, 2, 3 and 4 (each within the scatter of the next).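

Hydrogen in place of methyl on an aromatic carbon, ortho to a large group, is the first step here that changes only a substituent on the six-membered ring rather than exchanging one aryl group for another, and in this assay it reads no change at the digits printed from compound 3 to compound 4 (within the scatter). The plain phenyl group also matches the two other aryl groups, with no change at the digits printed from compound 2 to compound 4 (within the scatter) and no change at the digits printed from compound 1 to compound 4 (within the scatter). Four aryl groups at this position of the shared core, one of them carrying no substituent at all, therefore give the same read-out, and none of the four compounds stands apart from the others.

The compounds shown leave open whether an amine, a carboxylic acid or a longer chain on this ring, or any change elsewhere on the shared core, would move the read-out in this assay. No measurement at hand explains why the read-out stays the same across these four compounds.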